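Dialkylamino replacement on the amide aryl ring: compound 4

A few compounds are considered here, and "the series" means these few. Any claim that something is new, unique, unknown or untested is made for them only; others in the source may bear on it.

Three compounds share a core and differ only in the amino substituent on the aromatic carbon. In an assay on HEK293 cells for inhibition of Steryl-sulfatase (Homo sapiens), tested at 0.1 uM (on this read-out lower numbers stand for a weaker effect and higher numbers for a stronger effect at the one concentration tested), compound 3 `CCN(Cc1ccc(F)cc1)c1ccc(C(=O)N2CCc3ccc(OS(N)(=O)=O)cc3C2)cc1` gives 69.1%, the highest of the three. Compound 1 `CN(CCCN1CCCCC1)c1ccc(C(=O)N2CCc3ccc(OS(N)(=O)=O)cc3C2)cc1` gives 17.4%, and compound 2 `NS(=O)(=O)Oc1ccc2c(c1)CN(C(=O)c1ccc(N3CCCCC3)cc1)CC2` gives 11.5%. The steps of a number 51.7 percentage points higher from compound 1 to compound 3 (beyond the scatter) and a number 57.6 percentage points higher from compound 2 to compound 3 (beyond the scatter) are both large, whereas a number 5.9 percentage points lower from compound 1 to compound 2 (within the scatter) is within the scatter.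

Compound 4 `CCCN(CCC)c1ccc(C(=O)N2CCc3ccc(OS(N)(=O)=O)cc3C2)cc1` differs from compound 3 as follows: dipropylamino in place of ethyl(4-fluorobenzyl)amino on an aromatic carbon. The step 2>3 bears most directly on this: it introduced ethyl(4-fluorobenzyl)amino in place of a ring-bearing dialkylamino and was worth a number 57.6 percentage points higher from compound 2 to compound 3 (beyond the scatter). Going from compound 3 to compound 4 removes the ethyl(4-fluorobenzyl)amino group again and puts in a dialkylamino group without a ring, so a drop beyond the scatter is expected, probably toward the numbers of compound 1 and compound 2. The expected step is a number 44.1 percentage points lower from compound 3 to compound 4 (beyond the scatter). Compound 4 is estimated at 25%, with a range from 8% to 55%.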

Compound 4, a percentage reported as inhibition, at one concentration (the size of the read-out at that concentration, not a potency): 36.6%
Beside the measured number, compound 4's estimate is 11.6 percentage points below it; the range from low to high includes it.
By their numbers in this assay, from the lowest: compounds 2 and 1 (each within the scatter of the next); then compound 4; then compound 3.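

In this assay, dipropylamino, which has no ring, takes an intermediate place at this position: the change gives a number 32.5 percentage points lower from compound 3 to compound 4 (beyond the scatter), yet the same group also gives a number 25.1 percentage points higher from compound 2 to compound 4 (beyond the scatter) and a number 19.2 percentage points higher from compound 1 to compound 4 (beyond the scatter). Losing ethyl(4-fluorobenzyl)amino therefore does not by itself bring the read-out down to the lowest numbers of the set, and a purely open-chain dialkylamino group keeps part of the effect that piperidin-1-yl does not. Nothing available explains these differences.

The compounds shown leave open how much of the higher number of compound 3 belongs to the fluorine, the benzyl ring or the ethyl group. An ethyl(benzyl)amino group without fluorine and a dibutylamino group would help separate these contributions from the effect of chain length.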